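The source may report more compounds than this note shows. Statements on the series, on what has been measured and on what is new or still open speak of the compounds shown alone.

In a functional assay on HCT-15 cells (Homo sapiens) for cytotoxicity, read by sulforhodamine B assay (on this read-out lower numbers stand for stronger inhibition and higher numbers for weaker inhibition), compound 2 (`CNc1nc(-c2ccccc2)nc2ccccc12`) gives 21.2 ug/mL and compound 1 (`COCCNc1nc(-c2ccccc2)nc2ccccc12`) gives 26.8 ug/mL within the scatter of it, so neither number sets compound 2 apart. Compound 3 (`CN(C)CCN(C)c1nc(-c2ccccc2)nc2ccccc12`) has 2-(dimethylamino)ethyl in place of hydrogen on a nitrogen on an aromatic ring relative to compound 2. Among the measured compounds shown here, the only measured step, a 1.3-fold lower number from compound 1 to compound 2 (0.10 log units; within the scatter) on a saturated chain carbon, lies elsewhere and guides only loosely, so in this assay no step beyond the scatter is expected. Compound 3 is estimated at 16 ug/mL with an expected range of 6 ug/mL to 35 ug/mL for now. The estimate means a 1.3-fold lower number from compound 2 to compound 3 (0.12 log units; within the scatter) as the expected step.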

Compound 3, half-maximal inhibitory concentration: 26.5 ug/mL
Compound 3: middle estimate off by 1.7-fold (0.22 log units), on the low side; measured number inside the range.
By their numbers in this assay, from the lowest: compounds 2, 3 and 1 (each within the scatter of the next).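

On the nitrogen on the aromatic ring, 2-(dimethylamino)ethyl in place of hydrogen gives, in this assay, a 1.3-fold higher number from compound 2 to compound 3 (0.10 log units; within the scatter), so adding this chain there produces no step beyond the scatter. Replacing (2-methoxyethyl)amino on the aromatic carbon with (2-(dimethylamino)ethyl)(methyl)amino gives a 1.0-fold lower number from compound 1 to compound 3 (0.00 log units; within the scatter), so all three substituents shown at this place stay within the scatter of one another. Nothing available accounts for this result. On these data alone, whether a carboxylic acid, a morpholine ring or a longer chain at this place would give a step beyond the scatter remains open.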